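The source may report more compounds than this note shows. Statements on the series, on what has been measured and on what is new or still open speak of the compounds shown alone.

In a functional assay on HT-29 cells (Homo sapiens) for antiproliferative activity, read by sulforhodamine B assay, with a stated time of 48 h (on this read-out higher numbers stand for weaker inhibition and lower numbers for stronger inhibition), compound 1 (`CCCN1CCN(c2ccc(S(=O)(=O)Oc3cccc(OC)c3)cc2)C1=O`) gives 25000 nM. Compound 3 (`CCCN1CCN(c2ccc(S(=O)(=O)Oc3ccc(Cl)cc3)cc2)C1=O`) gives 15000 nM, and these two numerical values lie within the scatter of each other. Compound 2 (`CCCN1CCN(c2ccc(S(=O)(=O)Oc3cccc([N+](=O)[O-])c3)cc2)C1=O`) gives > 100000 nM, which is a limit of the assay and not a number.

Compound 4 (`CCCCN1CCN(c2ccc(S(=O)(=O)Oc3cccc(OC)c3)cc2)C1=O`) departs from compound 1 at the propyl chain: methyl in place of hydrogen on a saturated chain carbon, three bonds along the chain from an amide-type nitrogen in a ring. This places methyl in place of hydrogen on a saturated chain carbon, three bonds along the chain from an amide-type nitrogen in a ring, so that propyl becomes butyl.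

The measured steps all lie at the other end of the molecule, where the group on the sulfonate oxygen varies. They comprise an at least 4.0-fold higher number from compound 1 to compound 2 (0.60 log units; beyond the scatter), an at least 6.6-fold lower number from compound 2 to compound 3 (0.82 log units; beyond the scatter) and a 1.7-fold lower number from compound 1 to compound 3 (0.22 log units; within the scatter). Within the data shown here, none of them alters the chain, so they bear on this change only indirectly, and no measured step gives its size. Starting from compound 1 at 25000 nM, no step beyond the scatter is therefore expected in this assay, in either direction.

The expected step is a 1.3-fold lower number from compound 1 to compound 4 (0.10 log units; within the scatter). Compound 4 is estimated at 20000 nM, with an expected range from 7000 nM to 60000 nM.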

Compound 4, half-maximal inhibitory concentration: 13000 nM
Compound 4: the middle estimate sits 1.5-fold (0.19 log units) above what was measured; low and high end bracket the measured number.
By their numbers in this assay, from the lowest: compounds 4, 3 and 1 (each within the scatter of the next). At a limit, above all of these: compound 2.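

Among these compounds, the butyl chain of compound 4 gives the first measured step at the chain end of the molecule, where the earlier compounds varied only the group on the sulfonate oxygen: in this assay there is a 1.9-fold lower number from compound 1 to compound 4 (0.28 log units; within the scatter). Methyl in place of hydrogen on a saturated chain carbon, three bonds along the chain from an amide-type nitrogen in a ring, therefore leaves the number within the scatter, so that with the 3-methoxyphenyl group on the oxygen this position accepts butyl as well as propyl, with no loss of activity beyond the scatter. Nothing among the data shown accounts for this outcome.

The compounds shown leave open whether the chain can be taken further, since a hexyl chain, a branched chain such as isobutyl, or a chain ending in an amine or a carboxylic acid could still move the number beyond the scatter, and the shorter ethyl and methyl groups are equally open. They also leave open whether the change from propyl to butyl would read the same with 4-chlorophenyl on the oxygen as it does with 3-methoxyphenyl.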